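The source may report more compounds than this note shows. Statements on the series, on what has been measured and on what is new or still open speak of the compounds shown alone.

Measured compounds:
compound 1 `COc1cccc(C(=O)NN(C(=O)c2ccccc2Cl)C(C)(C)C)c1`, 52.5 nM in an assay on cells for agonist activity at ecdysone receptor (Bombyx mori), read by a luciferase reporter, with a stated time of 24 h; on this read-out lower numbers stand for an effect already at smaller amounts and higher numbers for an effect only at larger amounts of compound
compound 2 `COc1cccc(C(=O)NN(C(=O)c2ccccc2Cl)C(C)(C)C)c1C`, 15.5 nM
compound 3 `COc1cccc(C(=O)NN(C(=O)c2cc(C)cc(C)c2)C(C)(C)C)c1`, 66.1 nM

Compound 1 stands second highest of the three numbers. Its nearest neighbour is compound 3, reached by a 1.3-fold higher number from compound 1 to compound 3 (0.10 log units; within the scatter). Furthest from it is compound 2, reached by a 3.4-fold lower number from compound 1 to compound 2 (0.53 log units; beyond the scatter), a modest step.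

The unmeasured compound 4 `CCCCCCC(=O)NN(C(=O)c1ccccc1Cl)C(C)(C)C` differs from compound 1 in one place: hexyl in place of 3-methoxyphenyl on a carbonyl carbon.

Neither measured step bears closely on this change. The step from compound 1 to compound 3 swaps one aromatic acyl group for another and stays within the scatter; the step from compound 1 to compound 2 adds a methyl on an aromatic carbon and lowers the number modestly. Both measured variants keep both aromatic rings of the shared core, whereas compound 4 loses the 3-methoxyphenyl entirely and gains a hexyl chain. Among the compounds with values here, a change of this kind has no precedent among the three measured compounds, so the expectation rests on its size alone: it is expected to move the number well beyond the scatter, toward a higher number, by roughly a 29-fold higher number from compound 1 to compound 4 (1.46 log units; beyond the scatter).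

For compound 4 the estimate in this assay is therefore 1500 nM, with a range from 200 nM to 12000 nM.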

Compound 4, half-maximal effective concentration: 741 nM
For compound 4 the middle estimate is 2.0-fold (0.31 log units) above the measured one, within the range that was stated.
By their numbers in this assay, from the lowest: compound 2; then compounds 1 and 3 (each within the scatter of the next); then compound 4.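

In this assay, hexyl in place of 3-methoxyphenyl on this carbonyl carbon gives a 14-fold higher number from compound 1 to compound 4 (1.15 log units; beyond the scatter), a large step and the first among these compounds that takes away a ring instead of changing one. Within the data shown here, the earlier steps showed only what a methyl on an aromatic carbon and a change of the other aromatic acyl group do, so this is the first sign that the number depends strongly on what sits on this carbonyl carbon, though compound 4 still gives a measurable effect with no ring there at all. This single step removes the ring and the methoxy oxygen, the one hydrogen-bond acceptor of the group, together, and nothing shown explains why the number rises with this change.

The compounds shown leave open whether the rise follows the loss of the ring, the loss of the methoxy group or the chain itself. A plain phenyl or a cyclohexyl group on this carbonyl carbon would help to separate these, and a shorter or longer chain would show whether hexyl is a poor choice among chains or typical of them.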